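Chloro to methyl under a cytotoxicity limit

A few compounds are considered here, and "the series" means these few. Any claim that something is new, unique, unknown or untested is made for them only; others in the source may bear on it.

- compound 1 (`Cc1ccc2[nH]c(-c3cn(-c4ccccc4)nc3-c3ccccc3)nc2c1`) gives (> 50000 nM)
- compound 2 (`COc1ccc(-c2nn(-c3ccccc3)cc2-c2nc3cc(Cl)ccc3[nH]2)cc1`) gives (> 50000 nM)

Both entries come from an ADME assay on HaCaT cells (Homo sapiens) for cytotoxicity, read by MTT assay, with a stated time of 48 h (on this read-out higher numbers stand for weaker inhibition and lower numbers for stronger inhibition), and neither is a number. Compound 2 is recorded only as a limit (> 50000 nM). Compound 1 is also recorded only as a limit (> 50000 nM). Among the measured compounds shown here, the whole of the measured data therefore comes down to one entry (the limit of > 50000 nM in this assay, at which 2 of the 2 values shown sit), and no measured step exists from which to read a size.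

Compound 3 (`COc1ccc(-c2nn(-c3ccccc3)cc2-c2nc3cc(C)ccc3[nH]2)cc1`) is the next to be read. It differs from compound 2 by methyl in place of chloro on an aromatic carbon, on a six-membered aromatic ring of carbon only, part of a fused or bridged system of two rings.

In this assay no step beyond the usual scatter is expected, in either direction, and another limit is the likeliest report. The expected change is small (a step that the limit leaves unreadable from compound 2 to compound 3). For compound 3 the estimate is 60000 nM (expected range 30000 nM to 120000 nM).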

Compound 3, half-maximal inhibitory concentration: > 50000 nM
Compound 3: only a limit was reported; the forecaster's own chance of this, stated with the estimate: 85%; the middle value does not contradict the limit.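

Compound 3 is recorded only as a limit in this assay, at > 50000 nM. Compound 1 and compound 2 are limits too, so neither step to compound 3 can be read: the limit of > 50000 nM in this assay, at which 3 of the 3 values shown sit.

Still open, going by these compounds, is whether methyl in place of chloro changes cytotoxicity at all, and where any of the three compounds would give an actual number.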